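Swapping an Aryl Substituent for Methyl on the Core

This account rests on a few compounds, and the source may have more. Where it says the series, first, only, none or still open, it means among the compounds named here.

Compound 2 `COc1ccc(-c2c(Br)cn(Cc3ccc(F)cc3)c(=O)c2C(=O)NC2CCCCCC2)cc1` carries a 4-methoxyphenyl group on the shared core, while its companion compound 1 `O=C(NC1CCCCCC1)c1c(-c2ccccc2)c(Br)cn(Cc2ccc(F)cc2)c1=O` carries a plain phenyl group in the same place. In an ADME assay on cells for inhibition of Fatty-acid amide hydrolase 1 (Homo sapiens), with stated times of 30 min and 15 min (on this read-out lower numbers stand for stronger inhibition and higher numbers for weaker inhibition), compound 1 gives > 10000 nM, which is a limit of the assay rather than a measured number. Compound 2 gives > 10000 nM in this assay, again a limit and not a number. The step that the two limits leave unreadable from compound 1 to compound 2 cannot be read in size or direction because of the limit of > 10000 nM in this assay, at which 2 of the 2 values shown sit. Compound 2 thus stands at the limit, with no measured number to place it more precisely.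

Compound 3 `Cc1c(Br)cn(Cc2ccc(F)cc2)c(=O)c1C(=O)NC1CCCCCC1` differs from compound 2 in one place: methyl in place of 4-methoxyphenyl on an aromatic carbon. Going by the values given here, the only measured step, from compound 1 to compound 2, is unreadable, so no measured step gives a size or direction for this change. The expectation in this assay is that compound 3 stays at or near the limit, with an estimated step that the limit leaves unreadable from compound 2 to compound 3. Compound 3 is estimated at 15000 nM, within a range from 4000 nM to 60000 nM.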

Compound 3, half-maximal inhibitory concentration: 2300 nM
Compound 3: the middle estimate sits 6.5-fold (0.81 log units) above what was measured; measured number outside the range, below it.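

Going by these compounds alone, this position on the shared core, on an aromatic carbon ortho to a bromo group and ortho to a cycloheptylcarbamoyl group, now gives the first readable change in this assay. Methyl in place of 4-methoxyphenyl gives an at least 4.3-fold lower number from compound 2 to compound 3 (0.63 log units; beyond the scatter), and methyl in place of phenyl gives an at least 4.3-fold lower number from compound 1 to compound 3 (0.63 log units; beyond the scatter), so the group here does affect inhibition, and of the three groups shown only methyl brings the compound to a measured number. Both steps give only a minimum size because the two aryl compounds have limits rather than measured numbers: the limit of > 10000 nM in this assay, at which 2 of the 3 values shown sit.

The step between the phenyl and 4-methoxyphenyl compounds cannot be read, so these compounds do not show whether the methoxy group matters at this position. With methyl as the only non-aryl group shown, they also leave open whether the gain comes from losing the aromatic ring or from having fewer heavy atoms here, and how plain hydrogen, an ethyl chain or an amine would compare.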